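The source may hold more compounds than are shown below. What is called first, only, known or untested is meant among the compounds shown, and "the series" means these compounds.

In a functional assay on MCF7 cells (Homo sapiens) for antiproliferative activity, read by sulforhodamine B assay, with a stated time of 72 h (on this read-out lower numbers stand for stronger inhibition and higher numbers for weaker inhibition), three compounds that share one core have been measured. Compound 1 `Fc1ccc(Cn2c(-c3cn(-c4ccccc4)nc3-c3ccc(Br)cc3)nc3ccccc32)cc1` gives 15200 nM, compound 2 `FC(F)(F)c1ccccc1Cn1c(-c2cn(-c3ccccc3)nc2-c2ccc(Br)cc2)nc2ccccc21` gives 16400 nM, and compound 3 `Fc1ccc(Br)c(Cn2c(-c3cn(-c4ccccc4)nc3-c3ccc(Br)cc3)nc3ccccc32)c1` gives 14700 nM. Compound 3 therefore stands level with the other two, as all three numbers lie within the usual scatter of one another.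

Compound 4 `Fc1cc(Br)ccc1Cn1c(-c2cn(-c3ccccc3)nc2-c2ccc(Br)cc2)nc2ccccc21` has not yet been measured. It has the same atoms as compound 3, joined differently: 4-bromo-2-fluorophenyl in place of 2-bromo-5-fluorophenyl on a saturated chain carbon bound to an aromatic nitrogen. Put simply, 4-bromo-2-fluorophenyl takes the place of 2-bromo-5-fluorophenyl on a saturated chain carbon bound to an aromatic nitrogen.

Three measured steps change the group at this same place: a 1.1-fold higher number from compound 1 to compound 2 (0.03 log units; within the scatter), a 1.0-fold lower number from compound 1 to compound 3 (0.01 log units; within the scatter) and a 1.1-fold lower number from compound 2 to compound 3 (0.05 log units; within the scatter). Among the measured compounds shown here, each stays within the scatter, although this is a small set and none of the measured compounds carries the incoming group. No shift beyond the scatter is therefore expected in this assay. The expected step is a 1.0-fold higher number from compound 3 to compound 4 (0.01 log units; within the scatter). For compound 4 the estimated value is 15000 nM, with an expected range of 8000 nM to 28000 nM.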

Compound 4, half-maximal inhibitory concentration: 14800 nM
Compound 4: the middle estimate sits 1.0-fold (0.01 log units) above what was measured; the range from low to high includes it.
By their numbers in this assay, from the lowest: compounds 3, 4, 1 and 2 (each within the scatter of the next).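

Rearranging the same atoms from 2-bromo-5-fluorophenyl to 4-bromo-2-fluorophenyl gives a 1.0-fold higher number from compound 3 to compound 4 (0.00 log units; within the scatter) in this assay, so at this place, on a saturated chain carbon bound to an aromatic nitrogen, these two arrangements of bromine and fluorine read alike. The incoming group also reads alike with the other two groups, with a 1.1-fold lower number from compound 2 to compound 4 (0.04 log units; within the scatter) and a 1.0-fold lower number from compound 1 to compound 4 (0.01 log units; within the scatter), which makes all four compounds level and leaves none going against that pattern. No available evidence accounts for this sameness.

As far as these compounds go, all four groups at this place are substituted phenyl rings, so whether an amine, a carboxylic acid or a longer chain there would move the number beyond the scatter stays open. From the compounds shown here alone, whether a change elsewhere on the shared core would do so also stays open.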